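Swapping a flexible chain for a hydroxylated ring

This account rests on a few compounds, and the source may have more. Where it says the series, first, only, none or still open, it means among the compounds named here.

Measured compounds:
compound 1 `N#Cc1cnc(NCc2cnccc2C(F)(F)F)cc1N[C@H]1C[C@@H](O)C1` gives 500 nM
compound 2 `CO[C@H]1CC[C@@H](CNc2cc(NCc3cnccc3C(F)(F)F)ncc2C#N)CC1` gives 70 nM
compound 3 `N#Cc1cnc(NCc2cnccc2C(F)(F)F)cc1NCCC1CCOCC1` gives 1200 nM

In an assay on isolated protein for inhibition of protein kinase C theta type (Homo sapiens), read by TR-FRET, with a stated time of 2 h (a higher number here means a weaker inhibitor, a lower number a stronger inhibitor), compound 3 stands highest of the three, with a 2.4-fold higher number from compound 1 to compound 3 (0.38 log units; beyond the scatter) and a 17-fold higher number from compound 2 to compound 3 (1.23 log units; beyond the scatter) separating it from the other two. Compound 4 `CC1(C)C[C@@H](Nc2cc(NCc3cnccc3C(F)(F)F)ncc2C#N)CC[C@@H]1O` differs from compound 3 in one place: 4-hydroxy-3,3-dimethylcyclohexyl in place of 2-(oxan-4-yl)ethyl on a nitrogen on an aromatic ring. For the measured compounds named here, two measured steps bear on this. The step of a 2.4-fold higher number from compound 1 to compound 3 (0.38 log units; beyond the scatter) shows that moving from a ring carrying a hydroxyl directly on the nitrogen to the oxane-bearing chain raised the number, and a 7.1-fold lower number from compound 1 to compound 2 (0.85 log units; beyond the scatter) shows that a six-membered ring lowered it further. Since compound 4 carries a six-membered ring with a hydroxyl directly on the nitrogen, a step of a 6.0-fold lower number from compound 3 to compound 4 (0.78 log units; beyond the scatter) is expected. Compound 4 is therefore estimated at 200 nM, within 60 nM to 700 nM.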

Compound 4, half-maximal inhibitory concentration: 120 nM
Compound 4: middle estimate off by 1.7-fold (0.22 log units), on the high side; the range from low to high includes it.
By their numbers in this assay, from the lowest: compounds 2 and 4 (each within the scatter of the next); then compound 1; then compound 3.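

In this assay, 4-hydroxy-3,3-dimethylcyclohexyl on this nitrogen gives a 10-fold lower number from compound 3 to compound 4 (1.00 log units; beyond the scatter) and a 4.2-fold lower number from compound 1 to compound 4 (0.62 log units; beyond the scatter), so a hydroxyl-bearing ring placed directly on the nitrogen need not stay at the level of the cyclobutyl compound. With a 1.7-fold higher number from compound 2 to compound 4 (0.23 log units; within the scatter), this group and (4-methoxycyclohexyl)methyl are level, so two differently attached six-membered carbon rings reach the same range. Nothing measured here accounts for these differences.

On these data alone, how much of this rests on the hydroxyl and how much on the two methyl groups remains open, as does the outcome with an amine in place of the hydroxyl.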